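The source may report more compounds than this note shows. Statements on the series, on what has been measured and on what is new or still open speak of the compounds shown alone.

Compound 1 `CC(C)CCC(=O)Nc1c(C(O)(C(F)(F)F)C(F)(F)F)ccc2ccccc12` gives 49 nM in an assay on LtK cells with ATP-sensitive inward rectifier potassium channel 11 (Homo sapiens) as the target; a lower number here means that less compound is needed, a higher number that more compound is needed for the effect. Compound 2 `O=C(Nc1c(C(O)(C(F)(F)F)C(F)(F)F)ccc2ccccc12)C1CC1` gives 751 nM in this assay. Compound 3 `O=C(NCCCCCCCl)Nc1c(C(O)(C(F)(F)F)C(F)(F)F)ccc2ccccc12` gives 4840 nM in this assay.

Compound 3 stands highest of the three: a 99-fold higher number from compound 1 to compound 3 (1.99 log units; beyond the scatter) and a 6.4-fold higher number from compound 2 to compound 3 (0.81 log units; beyond the scatter). Compound 4 `CC(C)OC(=O)Nc1c(C(O)(C(F)(F)F)C(F)(F)F)ccc2ccccc12` differs from compound 3 by isopropoxy in place of (6-chlorohexyl)amino on a carbonyl carbon. Among the compounds with values here, two steps bear on this: a 99-fold higher number from compound 1 to compound 3 (1.99 log units; beyond the scatter) shows that leaving the (6-chlorohexyl)amino group brings a large drop, while a 15-fold higher number from compound 1 to compound 2 (1.19 log units; beyond the scatter) shows that a small group on the carbonyl carbon costs much of that gain. Isopropoxy is small, so only a modest drop is expected: a 3.2-fold lower number from compound 3 to compound 4 (0.51 log units; beyond the scatter). Compound 4 is therefore expected to give 1500 nM in this assay, between 400 nM and 6000 nM.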

Compound 4, half-maximal effective concentration: 1160 nM
Compound 4: the middle estimate sits 1.3-fold (0.11 log units) above what was measured; the range from low to high includes it.
By their numbers in this assay, from the lowest: compound 1; then compounds 2 and 4 (each within the scatter of the next); then compound 3.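

On this carbonyl carbon, isopropoxy sits well under (6-chlorohexyl)amino (a 4.2-fold lower number from compound 3 to compound 4 (0.62 log units; beyond the scatter)) but does not reach isopentyl (a 24-fold higher number from compound 1 to compound 4 (1.37 log units; beyond the scatter)). Isopropoxy and cyclopropyl cannot be told apart at this position in this assay (a 1.5-fold higher number from compound 2 to compound 4 (0.19 log units; within the scatter)), so this oxygen-linked group reads the same as a small carbon-linked one. No evidence available here accounts for these differences. The compounds shown leave open whether a longer alkoxy chain, such as isopentyloxy, would match isopentyl. They also leave open whether a short amine on the carbonyl carbon, such as isopropylamino, would behave like isopropoxy.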